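Hexyloxy to hexyl: estimate for compound 4

The compounds below may be only part of what the source reports. "The series", "measured", "known", "first", "only" and "open" are said of these compounds alone.

Measured so far:
compound 1 `CCCCCCOc1ccc2[nH]c(-c3ccc(OC)cc3)c(C3=C(Br)C(=O)NC3=O)c2c1` — 4.1
compound 2 `COc1cccc(-c2[nH]c3ccc(OC)cc3c2C2=C(Br)C(=O)NC2=O)c1` — 2.79
compound 3 `CCCCCCOc1ccc2[nH]c(-c3cccc(OC)c3)c(C3=C(Br)C(=O)NC3=O)c2c1` — 3.92

In a physicochemical assay for lipophilicity (a higher number here means a more lipophilic compound, a lower number a more polar compound), compound 3 stands second highest of the three: compound 1 lies nearest (a number 0.18 log units lower from compound 1 to compound 3 (within the scatter)) and compound 2 furthest (a number 1.13 log units higher from compound 2 to compound 3 (beyond the scatter)). Compound 4 `CCCCCCc1ccc2[nH]c(-c3cccc(OC)c3)c(C3=C(Br)C(=O)NC3=O)c2c1` follows from compound 3 by hexyl in place of hexyloxy on an aromatic carbon. Among the compounds with values here, no measured step removes an oxygen while keeping the chain. The step from compound 2 to compound 3 is the only one touching the chain carbons, and it was large; the step from compound 1 to compound 3 was within the scatter. Keeping the hexyl chain and dropping the oxygen is expected to give a modest rise in this assay, likely beyond the scatter: a number 0.48 log units higher from compound 3 to compound 4 (beyond the scatter). Compound 4 is therefore estimated at 4.4, range 3.9 to 4.9.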

Compound 4, partition coefficient: 4.26
Estimate against measurement, compound 4: 0.14 log units above, within the range that was stated.
By their numbers in this assay, from the lowest: compound 2; then compounds 3, 1 and 4 (each within the scatter of the next, the first and the last beyond it).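

Within the data shown here, for this assay the change of hexyloxy to hexyl on this aromatic carbon, with the chain kept and the oxygen gone, reads a number 0.34 log units higher from compound 3 to compound 4 (beyond the scatter) and so separates the oxygen from the chain for the first time. Hexyl in place of methoxy reads a number 1.47 log units higher from compound 2 to compound 4 (beyond the scatter) and stays large, so the larger part of the change at this carbon goes with the chain in the compounds shown. Nothing measured here explains either step.

Open, as far as these compounds go, is whether a longer chain or an amine at this carbon would follow the same direction. Also open, from the compounds shown here alone, is whether hexyl in place of hexyloxy gives a like step with the 4-methoxyphenyl of compound 1.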